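Removing the tert-butoxycarbonyl group from compound 1

The source may report more compounds than this note shows. Statements on the series, on what has been measured and on what is new or still open speak of the compounds shown alone.

Compound 1 `CC(C)(C)OC(=O)NCCS(=O)(=O)NC(=O)c1ccc(Nc2nc(NC3(c4ccc(Cl)cc4)CC3)nc(OCC(F)(F)F)n2)cc1` was tested in an ADME assay on microsomes from liver (Rattus norvegicus) for metabolic stability, with a stated time of 10 min (on this read-out lower numbers stand for a less stable compound and higher numbers for a more stable compound), where compound 1 gives 93%. Among the three measured compounds, compound 1 has the second highest number: compound 3 `CC(C)S(=O)(=O)NC(=O)c1ccc(Nc2nc(NC3(c4ccc(Cl)cc4)CC3)nc(OCC(F)(F)F)n2)cc1` gives 96%, and compound 2 `CC(C)C(=O)NCCS(=O)(=O)NC(=O)c1ccc(Nc2nc(NC3(c4ccc(Cl)cc4)CC3)nc(OCC(F)(F)F)n2)cc1` gives 84%. The step of a number 3 percentage points higher from compound 1 to compound 3 (within the scatter) and the step of a number 9 percentage points lower from compound 1 to compound 2 (within the scatter) both lie within the scatter, while the step of a number 12 percentage points higher from compound 2 to compound 3 (beyond the scatter) goes beyond it.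

Compound 4 `NCCS(=O)(=O)NC(=O)c1ccc(Nc2nc(NC3(c4ccc(Cl)cc4)CC3)nc(OCC(F)(F)F)n2)cc1` differs from compound 1 in one place: hydrogen in place of tert-butoxycarbonyl on an amine nitrogen. Going by the values given here, none of the measured steps makes this same change; all of them exchange groups on the carbonyl carbon or on the sulfonyl sulfur. The closest comparisons are the removal of the whole chain in the step of a number 3 percentage points higher from compound 1 to compound 3 (within the scatter) and the exchange at the carbonyl carbon in the step of a number 9 percentage points lower from compound 1 to compound 2 (within the scatter), both within the scatter. The step of a number 5 percentage points lower from compound 1 to compound 4 (within the scatter) is therefore expected to stay within the scatter. The estimate for compound 4 in this assay is 88%, with a range from 74% to 98%.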

Compound 4, percent of the compound remaining: 100%
Compound 4: middle estimate off by 12 percentage points, on the low side; measured number outside the range, above it.
By their numbers in this assay, from the lowest: compounds 2, 1, 3 and 4 (each within the scatter of the next, the first and the last beyond it).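

In this assay the free amine on the 2-aminoethyl chain holds up well: hydrogen in place of tert-butoxycarbonyl on the amine nitrogen gives a number 7 percentage points higher from compound 1 to compound 4 (within the scatter) and so the number does not rest on that carbamate group. The free chain and a plain isopropyl on the sulfonyl sulfur cannot be told apart, with a number 4 percentage points higher from compound 3 to compound 4 (within the scatter) as their step. What sits on this nitrogen can still count, since hydrogen in place of isopropylcarbonyl gives a number 16 percentage points higher from compound 2 to compound 4 (beyond the scatter) as a modest step.

From the compounds shown here alone, whether a methyl on this nitrogen, a longer chain carrying the amine or a carboxylic acid at the end of the chain would keep the number stays open. No measured information bears on why compound 2 is separated from compound 4 but not from compound 1.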